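The compounds below may be only part of what the source reports. "The series", "measured", "known", "first", "only" and "open" are said of these compounds alone.

Among the compounds with values here, compound 2 `C/C1=C\CC[C@@]2(C)O[C@@H]2[C@H]2OC(=O)[C@@H](CN3CCN(C)CC3)[C@@H]2C[C@H]1O` gives 33000 nM in a functional assay on Hs 683 cells (Homo sapiens) for inhibition, read by colorimetric assay and MTT assay, with a stated time of 72 h (a lower number here means a stronger inhibitor, a higher number a weaker inhibitor), the highest of the two numbers so far; compound 1 `C/C1=C\CC[C@@]2(C)O[C@@H]2[C@H]2OC(=O)[C@@H](CN3CCCCC3)[C@@H]2C[C@H]1O` gives 7000 nM. Compound 3 `C/C1=C\CC[C@@]2(C)O[C@@H]2[C@H]2OC(=O)[C@@H](CN3CCN(c4ccccc4F)CC3)[C@@H]2C[C@H]1O` differs from compound 2 by 2-fluorophenyl in place of methyl on an amine nitrogen in a ring. Within the data shown here, no measured step changes the group on the amine nitrogen in a ring; the only step known, a 4.7-fold higher number from compound 1 to compound 2 (0.67 log units; beyond the scatter), shows that altering the amine bound to the saturated chain carbon moves the number modestly. For compound 3 a modest shift of uncertain direction is therefore expected, a 1.7-fold lower number from compound 2 to compound 3 (0.22 log units; within the scatter). Compound 3 is estimated at 20000 nM, between 5000 nM and 80000 nM.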

Compound 3, half-maximal inhibitory concentration: 25000 nM
Compound 3: middle estimate off by 1.3-fold (0.10 log units), on the low side, within the range that was stated.
By their numbers in this assay, from the lowest: compound 1; then compounds 3 and 2 (each within the scatter of the next).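

In this assay, placing 2-fluorophenyl instead of methyl on the amine nitrogen in the ring gives a 1.3-fold lower number from compound 2 to compound 3 (0.12 log units; within the scatter). At this position, then, the much larger aromatic group, bearing a fluorine, leaves the number within the scatter, unlike the earlier step, which altered the whole amine. No measurement offered here explains this result. On these data alone, whether a plain phenyl, a benzyl or a chain ending in a carboxylic acid on this nitrogen would move the number beyond the scatter remains open, as does the contribution of the fluorine itself.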